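The compounds below may be only part of what the source reports. "The series", "measured", "known", "first", "only" and "open" are said of these compounds alone.

Measured compounds:
Compound 1, `S=C(N/N=C/c1ccccc1)N1CCNCC1`: 2410 nM
Compound 2, `C/C(=N\NC(=S)N1CCNCC1)c1ccc(Cl)cc1`: 260 nM
Compound 3, `C/C(=N\NC(=S)N1CCNCC1)c1cccc([N+](=O)[O-])c1`: 990 nM

In a functional assay on HBL-100 cells (Homo sapiens) for antiproliferative activity, read by MTT assay, with a stated time of 72 h (on this read-out higher numbers stand for weaker inhibition and lower numbers for stronger inhibition), compound 1 gives 2410 nM, the highest number of the three. Compound 3 gives 990 nM, and the gap between compound 1 and compound 3 lies beyond the scatter. Compound 2 gives 260 nM, the lowest of the three numbers, and its gap from compound 1 also lies beyond the scatter. Compound 1 is thus the weakest inhibitor among the measured compounds.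

Compound 4, `Oc1ccc(/C=N/NC(=S)N2CCNCC2)cc1`, has not yet been measured. It differs from compound 1 in one place: hydroxy in place of hydrogen on an aromatic carbon, sitting on an aromatic carbon of a six-membered aromatic ring of carbon only, para to a large group. Going by the values given here, no pair of measured compounds differs by this change alone, so the size of the step is not known from the data. In this assay the step from compound 1 to compound 4 is expected to be small, within the scatter, with a slight lean toward a lower number, a 1.3-fold lower number from compound 1 to compound 4 (0.13 log units; within the scatter). Compound 4 is accordingly estimated at 1800 nM, with a range from 600 nM to 5400 nM.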

Compound 4, half-maximal inhibitory concentration: 180 nM
Compound 4: middle estimate off by 10-fold (1.00 log units), on the high side; the measured number lies below the stated range.
By their numbers in this assay, from the lowest: compounds 4 and 2 (each within the scatter of the next); then compound 3; then compound 1.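

In this assay, hydroxy in place of hydrogen on an aromatic carbon, para to a large group, gives a 13-fold lower number from compound 1 to compound 4 (1.13 log units; beyond the scatter), a large step beyond the scatter. The earlier compounds shown here differ from one another in more than one place, so they could not show how much a change at this one position can matter. Here, a single added heavy atom on the ring of compound 1 is enough to produce a large change in the read-out, but no measurement shown explains why the step is so large.

As far as these compounds go, it remains open whether methoxy, an amine or a fluorine atom at this position would give a step of similar size, and so whether the effect is specific to hydroxy. It is also unknown whether hydroxy would give a similar step on another aromatic carbon of the same ring.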